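Second nitro group on compound 3

A few compounds are considered here, and "the series" means these few. Any claim that something is new, unique, unknown or untested is made for them only; others in the source may bear on it.

In an ADME assay on HEK-293T cells (Homo sapiens) for cytotoxicity, read by CCK-8 assay, with a stated time of 48 h (a higher number here means a weaker inhibitor, a lower number a stronger inhibitor), compound 3 `COc1ccc(NC(=O)NCCNS(=O)(=O)c2ccc(-c3ccccc3Oc3ccc([N+](=O)[O-])cc3)s2)cc1` gives only a limit, > 20000 nM. Compound 1 `COc1ccc(NC(=O)NCCNS(=O)(=O)c2ccc(-c3ccccc3OCc3ccccc3)s2)cc1` also gives only a limit, > 50000 nM. Going by the values given here, the one measured step, a step that the two limits leave unreadable from compound 1 to compound 3, therefore offers no usable size. Compound 4 `COc1ccc(NC(=O)NCCNS(=O)(=O)c2ccc(-c3ccccc3Oc3ccc([N+](=O)[O-])c([N+](=O)[O-])c3)s2)cc1` differs from compound 3 by nitro in place of hydrogen on an aromatic carbon, turning 4-nitrophenyl into 3,4-dinitrophenyl. The nearest guide is an isomer of compound 4 with the methoxy group placed differently. In this assay, compound 2 `COc1cccc(NC(=O)NCCNS(=O)(=O)c2ccc(-c3ccccc3Oc3ccc([N+](=O)[O-])c([N+](=O)[O-])c3)s2)c1` gives 17800 nM. On that single value, no step beyond the scatter is expected in this assay. The expected change is an at least 1.1-fold lower number from compound 3 to compound 4 (0.04 log units; that floor lies within the scatter). Compound 4 is estimated at 18000 nM, with an expected range of 8000 nM to 40000 nM.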

Compound 4, half-maximal inhibitory concentration: 18500 nM
Compound 4: middle estimate off by 1.0-fold (0.01 log units), on the low side; the range from low to high includes it.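

In this assay, the methoxy group's position on the dinitro compounds has no readable effect, with a 1.0-fold higher number from compound 2 to compound 4 (0.02 log units; within the scatter) for 4-methoxyphenyl in place of 3-methoxyphenyl. Going by these compounds alone, the swap of benzyl for 3,4-dinitrophenyl gives an at least 2.7-fold lower number from compound 1 to compound 4 (0.43 log units; beyond the scatter) as the only readable step beyond the scatter. The second nitro group gives only a floor, an at least 1.0-fold lower number from compound 3 to compound 4 (0.03 log units; that floor lies within the scatter) and compound 3 stays a limit: the limit of > 20000 nM in this assay, at which 1 of the 4 values shown sits.

On these data alone, the true size of the second nitro step remains open. So does whether an amine or a carboxylic acid in place of that nitro group would keep the number in this range.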